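A Dimethylamino Tail in Place of a Bulky Chain

The source may report more compounds than this note shows. Statements on the series, on what has been measured and on what is new or still open speak of the compounds shown alone.

Compound 1 `CCOC(CCn1c(Cc2nn(C)c(=O)c3ccccc23)nnc1SCCCCCCCC(=O)Nc1ccc(Cl)cc1Cl)OCC` carries a 3,3-diethoxypropyl group on an aromatic nitrogen of the shared core. In an assay on NK92 cells for inhibition of interleukin-2 (Homo sapiens), read by AlphaScreen, with stated times of 30 min and 1 h (a lower number here means a stronger inhibitor, a higher number a weaker inhibitor), compound 1 gives > 30000 nM, which is a limit of the assay and not a number. Compound 2 `Cn1nc(Cc2nnc(SCCCCCCCC(=O)Nc3ccc(Cl)cc3Cl)[nH]2)c2ccccc2c1=O` has a hydrogen on that nitrogen, and in this assay compound 2 gives 450 nM; the step is an at least 66-fold lower number from compound 1 to compound 2 (1.82 log units; beyond the scatter). Compound 3 `Cn1nc(Cc2nnc(SCCCCCCCC(=O)Nc3ccc(Cl)cc3Cl)n2CCCO[Si](C)(C)C(C)(C)C)c2ccccc2c1=O` carries a group containing silicon on the same nitrogen. In this assay compound 3 gives > 30000 nM, again a limit and not a number. The steps of an at least 66-fold higher number from compound 2 to compound 3 (1.82 log units; beyond the scatter) and a step that the two limits leave unreadable from compound 1 to compound 3 show that compound 3 stands at the limit of > 30000 nM in this assay, at which 2 of the 3 values shown sit, alongside compound 1. Compound 4 `CN(C)CCCn1c(Cc2nn(C)c(=O)c3ccccc23)nnc1SCCCCCCCC(=O)Nc1ccc(Cl)cc1Cl` is compound 3 with a group of 3 heavy atoms (2 carbon, 1 nitrogen; no ring) in place of a group of 8 heavy atoms (6 carbon, 1 oxygen, 1 silicon; no ring), on a saturated chain carbon, three bonds along the chain from an aromatic nitrogen. Both substituted nitrogens so far gave only limits, whereas the hydrogen of compound 2 gave a number, so a substituted nitrogen may again leave weak binding; still, the entering group is smaller, so some gain is expected as an at least 3.7-fold lower number from compound 3 to compound 4 (0.57 log units; beyond the scatter). Compound 4 is therefore estimated at 8000 nM, within 1500 nM to 30000 nM.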

Compound 4, half-maximal inhibitory concentration: > 30000 nM
Compound 4 ended at the assay's limit; the forecaster's own chance of this, stated with the estimate: 35%; middle value at least 3.7-fold (0.57 log units) from the limit.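

Placing dimethylamino at the end of the chain, in place of the larger group that holds silicon, brings no readable gain: in this assay compound 4 gives > 30000 nM, which is a limit of the assay and not a number. Putting 3-(dimethylamino)propyl in place of hydrogen on the aromatic nitrogen gives an at least 66-fold higher number from compound 2 to compound 4 (1.82 log units; beyond the scatter), while the steps among the limits cannot be read. Three different chain ends on that nitrogen, in compound 1, compound 3 and compound 4, now share one result: the limit of > 30000 nM in this assay, at which 3 of the 4 values shown sit.

The compounds shown leave open whether a small group on that nitrogen, such as methyl or ethyl, would keep a measurable value. They also leave open whether a carboxylic acid at the end of the propyl chain would do so.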